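A few compounds are considered here, and "the series" means these few. Any claim that something is new, unique, unknown or untested is made for them only; others in the source may bear on it.

In an ADME assay on MT4 cells (Homo sapiens) for cytotoxicity, with a stated time of 5 days (on this read-out lower numbers stand for higher toxicity in this test and higher numbers for lower toxicity in this test), compound 1 `CC1CC=C(C(=O)N(c2cc(C#CC(C)(C)C)sc2C(=O)O)C(C)C)CC1` gives > 20000 nM as a limit of the assay and not as a number. Compound 2 `CC(C)(C)C#Cc1cc(N(C(=O)[C@H]2CC[C@H](C)CC2)[C@H]2CC[C@@](O)(CO[C@H]3CCOC3)CC2)c(C(=O)O)s1` gives > 20000 nM and that too is only a limit. Compound 1 therefore stands with compound 2 at the limit of > 20000 nM in this assay, at which 2 of the 2 values shown sit, and no exact value is known for either. Compound 3 `CC(C)N(C(=O)C1CCCCCC1)c1cc(C#CC(C)(C)C)sc1C(=O)O` differs from compound 1 in one place, where cycloheptyl takes the place of 4-methylcyclohex-1-en-1-yl on a carbonyl carbon (cycloheptyl in place of 4-methylcyclohex-1-en-1-yl on a carbonyl carbon). Among the measured compounds shown here, no step between measured compounds is available as a guide, so no change beyond the usual scatter is expected in this assay and no direction can be given. The estimate for the change is a number no higher from compound 1 to compound 3 (the limit leaves the size open) and it is expected to stay within that scatter. For compound 3 the expected value is 20000 nM with an estimated range from 12000 nM to 40000 nM and the assay may again report only a limit.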

Compound 3, half-maximal cytotoxic concentration: > 20000 nM
Compound 3 ended at the assay's limit (the forecaster's own chance of this, stated with the estimate: 80%); the middle value sits exactly at the limit.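

Compound 1 and compound 3 both stand only at a limit in this assay, and no step can be read between them. The compounds shown leave open how far each lies from that limit, and whether cycloheptyl in place of 4-methylcyclohex-1-en-1-yl changes this read-out at all.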